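The source may report more compounds than this note shows. Statements on the series, on what has been measured and on what is new or still open speak of the compounds shown alone.

Of the compounds shown here, three sharing one core have been measured so far: compound 1 `O=C1C(Nc2ccc(I)cc2)=CC(=O)c2c1nc1n2[C@H]2OC[C@@H](O)[C@H]2OC1`, compound 2 `O=C1C=C(NCc2ccccc2)C(=O)c2c1nc1n2[C@H]2OC[C@@H](O)[C@H]2OC1` and compound 3 `COc1ccccc1NC1=CC(=O)c2nc3n(c2C1=O)[C@H]1OC[C@@H](O)[C@H]1OC3`. In a functional assay on MGC-803 cells (Homo sapiens) for inhibition, read by sulforhodamine B assay (on this read-out lower numbers stand for stronger inhibition and higher numbers for weaker inhibition), compound 1 gives 2150 nM, compound 2 gives 2670 nM and compound 3 gives 1630 nM, so all three lie within the scatter of one another, and compound 1 stands among them without any separation that the assay could confirm. The next compound, compound 4 `O=C1C(NCc2ccccc2)=CC(=O)c2c1nc1n2[C@H]2OC[C@@H](O)[C@H]2OC1`, arises from compound 1 by a single change: benzyl in place of 4-iodophenyl on an amine nitrogen. Among the measured compounds shown here, the one measured step that touches an aryl-for-benzyl swap on an amine nitrogen is a 1.6-fold lower number from compound 2 to compound 3 (0.21 log units; within the scatter), which runs in the opposite sense and stays within the scatter. Compound 2 also carries a benzyl group on an amine nitrogen and gives a number close to compound 1. On this basis the step is expected to be a 1.1-fold higher number from compound 1 to compound 4 (0.03 log units; within the scatter), that is, nothing beyond the scatter. Compound 4 is therefore estimated at 2300 nM, within a range from 1200 nM to 4500 nM.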

Compound 4, half-maximal inhibitory concentration: 3490 nM
The estimate for compound 4 lay 1.5-fold (0.18 log units) below the measured number, and the stated range covers the measured number.
By their numbers in this assay, from the lowest: compounds 3, 1, 2 and 4 (each within the scatter of the next, the first and the last beyond it).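

In this assay, putting benzyl in place of 4-iodophenyl on this amine nitrogen gives a 1.6-fold higher number from compound 1 to compound 4 (0.21 log units; within the scatter), so the assay cannot separate the two groups. The change removes the iodine and alters how the ring is attached to the nitrogen, yet both groups have the same count of heavy atoms and one six-membered aromatic ring of carbon only, and this pair gives no confirmed sign that either feature matters here. No supporting data are available to explain the size of this step.

An unsubstituted phenyl group on this nitrogen would be needed to look at the iodine apart from the attachment of the ring. From the compounds shown here alone, it also remains open whether a group without an aromatic ring, such as a longer alkyl chain, a carboxylic acid or a basic amine, would move the number beyond the scatter.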